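Bringing back a bromophenyl group on the amine nitrogen

The compounds below may be only part of what the source reports. "The series", "measured", "known", "first", "only" and "open" are said of these compounds alone.

For the measured compounds named here, compound 2, `N#CC1=C(NC(N)=O)N(c2ccc(S(N)(=O)=O)cc2)C2=C(C(=O)CCC2)C1c1ccc(Cl)cc1Cl`, is the weaker of the two compounds measured so far. In a functional assay on Ehrlich cells (Mus musculus) for cytotoxicity, read by trypan blue exclusion, with a stated time of 2 h, tested at 100 ug/mL (a higher number here means a stronger effect of the compound at the concentration tested, a lower number a weaker effect), compound 2 gives 60%, while compound 1, `N#CC1=C(NC(=S)Nc2ccc(Br)cc2)N(c2ccc(S(N)(=O)=O)cc2)C2=C(C(=O)CCC2)C1c1ccc(Cl)cc1Cl`, gives 90%. Going by the values given here, the only step measured, a number 30 percentage points lower from compound 1 to compound 2 (beyond the scatter), came with a small carbamoyl group replacing a larger group that carried a bromophenyl ring on the same amine nitrogen, and it lowered the read-out beyond the scatter.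

Compound 3, `N#CC1=C(NS(=O)(=O)c2ccc(Br)cc2)N(c2ccc(S(N)(=O)=O)cc2)C2=C(C(=O)CCC2)C1c1ccc(Cl)cc1Cl`, has not yet been measured. It differs from compound 2 in one place: (4-bromophenyl)sulfonyl in place of carbamoyl on an amine nitrogen. Among the compounds with values here, this change again puts a larger group with a bromophenyl ring where the small carbamoyl sat, so the one measured step bears on it directly, though the linking atoms differ. An increase is therefore expected, with the step of a number 20 percentage points higher from compound 2 to compound 3 (beyond the scatter) for compound 3. The read-out of compound 3 is estimated at 80%, within a range from 60% to 95%.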

Compound 3, a percentage reported as activity, at one concentration (the size of the read-out at that concentration, not a potency): 100%
The estimate for compound 3 lay 20 percentage points below the measured number, and the stated range ends below it.
By their numbers in this assay, from the lowest: compound 2; then compounds 1 and 3 (each within the scatter of the next).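

In this assay, (4-bromophenyl)sulfonyl in place of carbamoyl on the amine nitrogen gives a number 40 percentage points higher from compound 2 to compound 3 (beyond the scatter), so a second large group with a bromophenyl ring, joined through different linking atoms, also stands clear of the small carbamoyl. The comparison with the group of compound 1 gives a number 10 percentage points higher from compound 1 to compound 3 (within the scatter), so exchanging the link while keeping the bromophenyl ring produces no difference that can be told apart from the scatter. Nothing measured here explains why the read-out follows these groups.

The compounds shown leave open whether the bromine, the aromatic ring or simply the larger group goes with the higher read-out; a plain phenylsulfonyl or a small methanesulfonyl on the same nitrogen would separate these. With compound 3 at 100% at a single concentration, this read-out also leaves open how potent these compounds are.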